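Step from compound 2 to a morpholine amide

This account rests on a few compounds, and the source may have more. Where it says the series, first, only, none or still open, it means among the compounds named here.

Compound 2 `CC(C(=O)N1C[C@H]2CCC[C@H]2C1)N1CCN(S(=O)(=O)c2ccc(C(C)(C)C)cc2)CC1` in an ADME assay on HepG2 cells (Homo sapiens) for inhibition, with a stated time of 48 h (a lower number here means that less compound is needed, a higher number that more compound is needed for the effect), gives > 40000 nM, a limit of the assay and not a number.
Compound 1 `C[C@@H](C(=O)N1CC2CC2C1)N1CCN(S(=O)(=O)c2ccc(C(C)(C)C)cc2)CC1` in this assay gives > 40000 nM, again a limit.
Compound 3 `C[C@H](C(=O)N1CCCCC1)N1CCN(S(=O)(=O)c2ccc(C(C)(C)C)cc2)CC1` in this assay gives > 40000 nM, also a limit.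

Going by the values given here, compound 2 therefore stands nowhere in particular among the three: every measured compound sits at the limit of > 40000 nM in this assay, at which 3 of the 3 values shown sit, and no compound can be told apart from another on these numbers. Compound 4 `CC(C(=O)N1CCOCC1)N1CCN(S(=O)(=O)c2ccc(C(C)(C)C)cc2)CC1` differs from compound 2 at the carbonyl carbon, where (a group of 6 heavy atoms (4 carbon, 1 nitrogen, 1 oxygen; one six-membered non-aromatic ring with 2 hetero atoms) in place of a group of 8 heavy atoms (7 carbon, 1 nitrogen; one five-membered non-aromatic ring of carbon only, one five-membered non-aromatic ring with 1 hetero atom), on a carbonyl carbon); in words, a group of 6 heavy atoms (4 carbon, 1 nitrogen, 1 oxygen; one six-membered non-aromatic ring with 2 hetero atoms) replaces a group of 8 heavy atoms (7 carbon, 1 nitrogen; one five-membered non-aromatic ring of carbon only, one five-membered non-aromatic ring with 1 hetero atom). Among the compounds with values here, no step between measured compounds is available, and the three amides of different size all return the same limit, so no change beyond the scatter is expected in this assay in either direction. Compound 4 is estimated at 60000 nM, with a range from 20000 nM to 200000 nM, most likely reported as a limit again; the expected step is a step that the limit leaves unreadable from compound 2 to compound 4.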

Compound 4, half-maximal effective concentration: > 40000 nM
Compound 4 gave a limit, no number; the forecaster's own chance of this, stated with the estimate: 85%; the middle value does not contradict the limit.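

In this assay compound 4 gives > 40000 nM, a limit and not a number. Compound 2 also stands at a limit, so no step can be read between compound 2 and compound 4. The compounds shown leave open whether any of these amides would give a readable half-maximal effective concentration in this assay.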